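Cytotoxicity of the shared core with substituted aryl groups

The compounds below may be only part of what the source reports. "The series", "measured", "known", "first", "only" and "open" are said of these compounds alone.

Measured so far in an ADME assay on Huh-7 cells (Homo sapiens) for cytotoxicity; on this read-out lower numbers stand for higher toxicity in this test and higher numbers for lower toxicity in this test:
compound 1 `O=c1cc(CNCc2ccccc2)oc2ccc(O)c(O)c12`, > 100000 nM
compound 2 `O=c1cc(CNCc2cccc(Cl)c2)oc2ccc(O)c(O)c12`, > 100000 nM

Compound 1 stands only at a limit in this assay: its value of > 100000 nM is the upper limit of the measurement and not a number. Compound 2 likewise gives > 100000 nM, which is a limit. The step that the two limits leave unreadable from compound 1 to compound 2 therefore cannot be sized; both values sit at the limit of > 100000 nM in this assay, at which 2 of the 2 values shown sit, so nothing in the measured pair shows a change beyond the scatter.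

Compound 3 `O=c1cc(CNCc2ccc([N+](=O)[O-])cc2)oc2ccc(O)c(O)c12` is not yet measured. Its change from compound 1 is nitro in place of hydrogen on an aromatic carbon. Among the compounds with values here, the only measured step, from compound 1 to compound 2, bears on it as an aromatic substitution on the same ring, and it was unreadable between two limits. No other evidence on this assay exists for the series.

Compound 3 is therefore expected to show no step beyond the scatter, with a number no higher from compound 1 to compound 3 (the limit leaves the size open) estimated near zero. Compound 3 is estimated at 100000 nM, within 30000 nM to 200000 nM, most likely reported again as a limit.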

Compound 3, half-maximal cytotoxic concentration: 73300 nM
Compound 3: the middle estimate sits 1.4-fold (0.13 log units) above what was measured, and the stated range covers the measured number.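

In this assay, nitro in place of hydrogen on an aromatic carbon, para to a large group, gives the series its first number rather than a limit, with an at least 1.3-fold lower number from compound 1 to compound 3 (0.13 log units; that floor lies within the scatter). Within the data shown here, this is the first sign that a substituent on this ring can bring a readable cytotoxic concentration within the range of the test, whereas the chloro change of compound 2 left a step that cannot be read. That sign is weak, since the printed floor of the step does not clear the scatter and its true size stays unknown, with compound 1 held at a limit: the limit of > 100000 nM in this assay, at which 2 of the 3 values shown sit.

As far as these compounds go, whether the step from hydrogen to nitro is in fact larger than the scatter stays open, as does whether nitro on another carbon of the same ring would give a number or a limit in this assay. Also open, from the compounds shown here alone, is what an amine or a carboxylic acid on the same aromatic carbon would give, so no trend across substituents can yet be drawn for this position.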